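The compounds below may be only part of what the source reports. "The series", "measured", "known", "first", "only" and "open" are said of these compounds alone.

Compound 1 `C/C(=C\CC/C(C)=C/CC[C@@H]1[C@@]2(C)CCC(=O)C(C)(C)[C@H]2CC[C@@]1(C)O)CC/C=C(\C)C(=O)OCc1cn(-c2ccc([N+](=O)[O-])cc2)nn1`, compound 2 `C/C(=C\CC/C(C)=C/CC[C@@H]1[C@@]2(C)CCC(=O)C(C)(C)[C@H]2CC[C@@]1(C)O)CC/C=C(\C)C(=O)OCc1cn(-c2ccccc2C(F)(F)F)nn1` and compound 3 `C/C(=C\CC/C(C)=C/CC[C@@H]1[C@@]2(C)CCC(=O)C(C)(C)[C@H]2CC[C@@]1(C)O)CC/C=C(\C)C(=O)OCc1cn(-c2cccc(Br)c2)nn1` share one core and differ only in the aryl group on an aromatic nitrogen. In a functional assay on DU-145 cells (Homo sapiens) for antiproliferative activity, read by MTT assay, with a stated time of 48 h (on this read-out lower numbers stand for stronger inhibition and higher numbers for weaker inhibition), compound 1 gives > 150000 nM, which is a limit and not a number. Compound 2 gives > 150000 nM, also a limit. Compound 3 gives > 150000 nM, again a limit. Compound 3 thus stands at the limit of > 150000 nM in this assay, at which 3 of the 3 values shown sit.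

Compound 4 `COc1ccc(-n2cc(COC(=O)/C(C)=C/CC/C(C)=C/CC/C(C)=C/CC[C@@H]3[C@@]4(C)CCC(=O)C(C)(C)[C@H]4CC[C@@]3(C)O)nn2)cc1` comes from compound 3 through one change, 4-methoxyphenyl in place of 3-bromophenyl on an aromatic nitrogen. The measured steps that bear on this change swap the group at the same place. They are a step that the two limits leave unreadable from compound 1 to compound 2, a step that the two limits leave unreadable from compound 1 to compound 3 and a step that the two limits leave unreadable from compound 2 to compound 3. None of them has a readable size, so they give no direction for the new group. In this assay, a further limit is therefore the expected result for compound 4 because of the limit of > 150000 nM in this assay, at which 3 of the 3 values shown sit. No step beyond the usual scatter can be forecast, and the expected outcome is a step that the limit leaves unreadable from compound 3 to compound 4. Should a number appear, compound 4 is estimated at 180000 nM, with an expected range from 70000 nM to 400000 nM.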

Compound 4, half-maximal inhibitory concentration: 135000 nM
Compound 4: the middle estimate sits 1.3-fold (0.12 log units) above what was measured; the range from low to high includes it.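

Compound 4, with its 4-methoxyphenyl on the aromatic nitrogen of the five-membered ring, is the only one of the four compounds shown that gives a number and not a limit in this assay: compound 4 gives 135000 nM. Set against the other aryl groups, the result is an at least 1.1-fold lower number from compound 3 to compound 4 (0.04 log units; that floor lies within the scatter), an at least 1.1-fold lower number from compound 2 to compound 4 (0.04 log units; that floor lies within the scatter) and an at least 1.1-fold lower number from compound 1 to compound 4 (0.04 log units; that floor lies within the scatter), so each step has a readable floor, but every floor lies within the scatter and none shows a real gain from the change. The series still gathers at the assay limit, with compound 4 the one exception: the limit of > 150000 nM in this assay, at which 3 of the 4 values shown sit.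

As far as these compounds go, the steps among compound 1, compound 2 and compound 3 still cannot be read, and the true distance of each from compound 4 remains unknown. The compounds shown also leave open whether an amine or a carboxylic acid on the phenyl ring, or a longer chain in place of the methoxy, would give a number clearly beyond the scatter from that of compound 4 in this assay.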